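This account rests on a few compounds, and the source may have more. Where it says the series, first, only, none or still open, it means among the compounds named here.

Measured compounds:
- compound 1 `O=C(Nc1cccc(-n2cc(-c3ccncc3)c(-c3ccc(Cl)c(O)c3)n2)c1)Nc1cccc(C(F)(F)F)c1`: 2020 nM
- compound 2 `COc1cc(-c2nn(-c3cccc(NC(=O)Nc4cc(C(F)(F)F)cc(C(F)(F)F)c4)c3)cc2-c2ccncc2)ccc1Cl`: 1020 nM

Both numbers come from a functional assay on SK-MEL-2 cells (Homo sapiens) for inhibition, read by sulforhodamine B assay, with a stated time of 48 h; a higher number here means a weaker inhibitor of growth, a lower number a stronger inhibitor of growth. Compound 1 gives 2020 nM in this assay, and compound 2 gives 1020 nM. Compound 2 has the lower of the two numbers, but its nearest neighbour, compound 1, sits only within the scatter of it, so the two cannot be ordered. Compound 1 and compound 2 differ from each other in more than one place, so no single step can be read from the pair.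

Compound 3 `O=C(Nc1cccc(-n2cc(-c3ccncc3)c(-c3ccc(Cl)c(O)c3)n2)c1)Nc1cc(C(F)(F)F)cc(C(F)(F)F)c1` has not been measured in this assay. It differs from compound 2 in one place: hydrogen in place of methyl on an oxygen on an aromatic ring. Compound 1 already carries a hydroxy at this place, and its number in this assay is within the scatter of compound 2, which gives no sign that this change by itself moves the number far.

For compound 3 no step beyond the scatter is expected, the estimated step being a 1.2-fold higher number from compound 2 to compound 3 (0.07 log units; within the scatter). The estimate for compound 3 in this assay is 1200 nM, with a range from 500 nM to 3000 nM.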

Compound 3, concentration for 50% growth inhibition: 1250 nM
Compound 3: middle estimate off by 1.0-fold (0.02 log units), on the low side; the range from low to high includes it.
By their numbers in this assay, from the lowest: compounds 2, 3 and 1 (each within the scatter of the next).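

In this assay, the exchange of methoxy for hydroxy on the 4-chloro-3-methoxyphenyl group gives a 1.2-fold higher number from compound 2 to compound 3 (0.09 log units; within the scatter), so this first comparison at that oxygen shows no readable effect of removing the methyl. Compound 3 also supplies a single-place comparison for the trifluoromethyl substitution, which the opening pair could not provide: trifluoromethyl in place of hydrogen on an aromatic carbon gives a 1.6-fold lower number from compound 1 to compound 3 (0.21 log units; within the scatter), so neither change can be distinguished from the scatter in these compounds. No measurement at hand bears on why these two changes leave the numbers within the scatter.

Still open, on these data alone, is whether an amine in place of the hydroxy, or a longer chain such as ethoxy on the same oxygen, would move the number beyond the scatter. Also open, as far as these compounds go, is whether a nitrile or a carboxylic acid in place of a trifluoromethyl group would produce a step that can be read in this assay.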